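Benzyl to Hydrogen on the Oxygen: One Change, Two Pairs

A few compounds are considered here, and "the series" means these few. Any claim that something is new, unique, unknown or untested is made for them only; others in the source may bear on it.

Measured compounds:
compound 1, `O=C(CN(c1nc(Cl)nc2[nH]cnc12)C1CC1)N[C@@H](CO)C(=O)OCc1ccccc1`, 31.9%
compound 2, `O=C(CN(c1nc(Cl)nc2[nH]cnc12)C1CC1)N[C@@H](CO)C(=O)O`, 38.7%
compound 3, `CC(C)C[C@H](NC(=O)CN(c1nc(Cl)nc2[nH]cnc12)C1CC1)C(=O)OCc1ccccc1`, 33.9%

All three values come from a functional assay on the whole organism (Tail, strain ICR) with Mus musculus as the target, in the tail flick test, with a stated time of 30 min, at a dose of 25 umol/kg by the oral route; on this read-out lower numbers stand for a weaker effect and higher numbers for a stronger effect at the one dose given. Compound 2 is compound 1 with hydrogen in place of benzyl on an oxygen next to a carbonyl group; this gave a number 6.8 percentage points higher from compound 1 to compound 2 (within the scatter). Compound 3 is compound 1 with isopropyl in place of hydroxy on a saturated chain carbon, two bonds along the chain from an amide-type nitrogen and a carbonyl carbon, and here the two values are within the scatter of each other, as a number 2 percentage points higher from compound 1 to compound 3 (within the scatter) shows. The not yet measured compound 4, `CC(C)C[C@H](NC(=O)CN(c1nc(Cl)nc2[nH]cnc12)C1CC1)C(=O)O`, is compound 3 carrying (hydrogen in place of benzyl on an oxygen next to a carbonyl group). The place of this change reads word for word as in the pair of compound 1 and compound 2, so it is the same change, made a second time on a core that differs as described above. For the measured compounds named here, the only measured example of this change moved the number by a small amount that lies within the scatter; the second occurrence rests on one example and on the value of compound 3 alone, so the expectation is wide. The step from compound 3 to compound 4 in this assay is expected to be about a number 6.1 percentage points higher from compound 3 to compound 4 (within the scatter), in line with the earlier step. Compound 4 is therefore estimated at 40%, with a likely range from 27% to 53%.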

Compound 4, a percentage reported as activity, at one dose (the size of the read-out at that dose, not a potency): 23.4%
Estimate against measurement, compound 4: 16.6 percentage points above, and the stated range ends above it.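

In this assay, hydrogen in place of benzyl on the oxygen gave a number 10.5 percentage points lower from compound 3 to compound 4 (beyond the scatter), and isopropyl in place of hydroxy on the saturated chain carbon gave a number 15.3 percentage points lower from compound 2 to compound 4 (beyond the scatter). Taken across these four compounds, the step for removing benzyl is not the same on both cores, so the result from one pair could not simply be carried over to the other: the same change on two cores in this assay, a number 6.8 percentage points higher (within the scatter) from compound 1 to compound 2 and a number 10.5 percentage points lower (beyond the scatter) from compound 3 to compound 4, 17.3 percentage points apart, beyond the scatter of two such steps The isopropyl change gives the same picture, but with only one pair on each core, this shows a dependence on the core for a single read-out at a single dose and neither explains that dependence nor gives a rule for other cores: the same change on two cores in this assay, a number 2 percentage points higher (within the scatter) from compound 1 to compound 3 and a number 15.3 percentage points lower (beyond the scatter) from compound 2 to compound 4, 17.3 percentage points apart, beyond the scatter of two such steps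

The compounds shown leave open how other groups on the same saturated chain carbon, such as an amine or a longer chain, would behave with and without the benzyl. Also open, on these data alone, is whether a methyl ester or a primary amide in place of the carboxy group would follow compound 3, compound 4 or neither in this assay.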